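A third aryl ether after two limits

The source may hold more compounds than are shown below. What is called first, only, known or untested is meant among the compounds shown, and "the series" means these compounds.

Compound 1 `COc1cc(OC)c(/C=C/C(=O)/C=C/c2cc3ccccc3nc2Oc2ccc(Br)cc2)c(OC)c1`: > 10000 nM
Compound 2 `COc1cc(OC)c(/C=C/C(=O)/C=C/c2cc3ccccc3nc2Oc2cccc(Cl)c2)c(OC)c1`: > 10000 nM

In a functional assay on 4T1 cells (Mus musculus) for cytotoxicity, read by MTT assay, with a stated time of 48 h (a higher number here means a weaker inhibitor, a lower number a stronger inhibitor), compound 1 sits at a limit, > 10000 nM. Compound 2 also sits at a limit, > 10000 nM. So the only evidence is the limit of > 10000 nM in this assay, at which 2 of the 2 values shown sit, and the one measured step, a step that the two limits leave unreadable from compound 1 to compound 2, has no readable size.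

Compound 3 `COc1cc(OC)c(/C=C/C(=O)/C=C/c2cc3ccccc3nc2Oc2ccccc2C(C)C)c(OC)c1` carries 2-isopropylphenyl in place of 3-chlorophenyl on an oxygen on an aromatic ring. With no readable step to go on, no clear change in either direction is expected in this assay. The expected step is a number no higher from compound 2 to compound 3 (the limit leaves the size open). Compound 3 is estimated at 10000 nM, with an expected range of 3000 nM to 30000 nM, and another limit is likely.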

Compound 3, half-maximal inhibitory concentration: > 10000 nM
Compound 3: a limit, no number; the forecaster's own chance of this, stated with the estimate: 70%; the middle value sits exactly at the limit.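

Compound 3 gives > 10000 nM in this assay, which is a limit and not a number, so the steps to it from compound 1 and compound 2 cannot be read. The compounds shown leave open whether changing the group on the oxygen alters activity at all: the limit of > 10000 nM in this assay, at which 3 of the 3 values shown sit.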